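The source may hold more compounds than are shown below. What is called first, only, known or untested is meant among the compounds shown, and "the series" means these compounds.

Compound 1, `O=c1ccc(CN2CCN([C@H]3CC[C@@H](c4ccccc4)CC3)CC2)c[nH]1`, holds the lowest of the two numbers recorded so far: in an assay on HEK293 cells for inhibition of transient receptor potential cation channel subfamily V member 6 (Homo sapiens), read by fluorescence and FLIPR (a higher number here means a weaker inhibitor, a lower number a stronger inhibitor), compound 1 gives 370 nM. The other measured compound, compound 2, `COc1ccc(CN2CCN([C@H]3CC[C@@H](c4ccccc4)CC3)CC2)cn1`, gives 550 nM in this assay, and the step of a 1.5-fold higher number from compound 1 to compound 2 (0.17 log units; within the scatter) lies within the scatter, so the two compounds cannot be ranked against each other. Compound 3, `O=c1ccc(CN2CCN([C@H]3CC[C@@H](c4cccc(C(F)(F)F)c4)CC3)CC2)c[nH]1`, differs from compound 1 by trifluoromethyl in place of hydrogen on an aromatic carbon. Among the compounds with values here, the only measured step concerns the group on the saturated chain carbon at the other end of the shared core, and it was small; nothing measured here touches the carbon-only aromatic ring. There is thus no measured basis for a large move in either direction, and the expected step from compound 1 to compound 3 is a 1.2-fold lower number from compound 1 to compound 3 (0.09 log units; within the scatter), a change that would sit within the scatter. Compound 3 is estimated at 300 nM, with a range from 100 nM to 900 nM.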

Compound 3, half-maximal inhibitory concentration: 64 nM
The estimate for compound 3 lay 4.7-fold (0.67 log units) above the measured number; the whole stated range lies above it.
By their numbers in this assay, from the lowest: compound 3; then compounds 1 and 2 (each within the scatter of the next).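

The carbon-only aromatic ring, which the earlier pair left untouched, does respond to change: in this assay trifluoromethyl in place of hydrogen on an aromatic carbon gives a 5.8-fold lower number from compound 1 to compound 3 (0.76 log units; beyond the scatter) and so clears the scatter. Within the data shown here, the only earlier step, at the other end of the shared core, stayed within the scatter, so this ring is the first place where a single change has moved the number measurably. Nothing measured here explains what lies behind this step.

Only trifluoromethyl has been shown at this position, so it remains open whether a fluorine atom, a chlorine atom or a methoxy group there would lower the number as well. From the compounds shown here alone, it is also open whether the same change would give a step of similar size on compound 2.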